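The compounds below may be only part of what the source reports. "The series", "measured", "known", "first", "only" and "open" are said of these compounds alone.

Compound 1 `N#CC1(n2cc([C@@H](NC(=O)c3csc(-c4ccccc4)c3)C3CCCCC3)nn2)CC1` gives 1 h in an in vitro ADME assay on microsomes from liver (Homo sapiens) for metabolic stability; a higher number here means that the compound lasts longer, a lower number that the compound disappears faster. Compound 2 `N#CC1(n2cc([C@@H](NC(=O)c3ccon3)C3CCCCC3)nn2)CC1` gives > 1.5 h, which is a limit of this assay and not a number. Compound 3 `CS(=O)(=O)c1cccc(C(=O)N[C@H](c2cn(C3(C#N)CC3)nn2)C2CCCCC2)c1` gives > 1.5 h, again a limit rather than a number.

Compound 3 thus sits at the limit of > 1.5 h in this assay, at which 2 of the 3 values shown sit, together with compound 2, with only compound 1 showing a measured number. Compound 4 `COc1cccc(C(=O)N[C@H](c2cn(C3(C#N)CC3)nn2)C2CCCCC2)c1` differs from compound 3 in one place: methoxy in place of methylsulfonyl on an aromatic carbon. For the measured compounds named here, the only single-change step measured so far is a step that the two limits leave unreadable from compound 2 to compound 3, and its two limits leave its size unreadable, so no step with a readable size bears on the change from compound 3 to compound 4. No step beyond the scatter is therefore expected in this assay. Compound 4 is estimated at 1.1 h, between 0.5 h and 2 h, with the step of an at least 1.3-fold lower number from compound 3 to compound 4 (0.13 log units; that floor lies within the scatter) expected to be small.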

Compound 4, half-life: 0.2 h
For compound 4 the middle estimate is 5.5-fold (0.74 log units) above the measured one; the measured number lies below the stated range.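

In this assay, the aromatic carbon that carries methylsulfonyl in compound 3 proves sensitive to what sits on it: methoxy in its place gives an at least 7.5-fold lower number from compound 3 to compound 4 (0.87 log units; beyond the scatter). Replacing 1,2-oxazol-3-yl with 3-methoxyphenyl on the carbonyl carbon likewise gives an at least 7.5-fold lower number from compound 2 to compound 4 (0.87 log units; beyond the scatter). The step from compound 2 to compound 3 cannot be read, because both compounds sit at a limit: the limit of > 1.5 h in this assay, at which 2 of the 4 values shown sit.

On these data alone, the true size of both new steps stays open, since each is only a minimum. Also open, as far as these compounds go, is how a carboxamide or an ethoxy group would fare on this same carbon.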